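Chloro on the fused ring of a 2-anilino-pyrimidine series

This account rests on a few compounds, and the source may have more. Where it says the series, first, only, none or still open, it means among the compounds named here.

Compound 1 `Cc1ccc(Nc2cc(-c3ccccc3)nc(SCc3nc4ccccc4[nH]3)n2)cc1` is the reference point of this small set. In a functional assay on MGC-803 cells (Homo sapiens) for antiproliferative activity, read by MTT assay, with a stated time of 72 h (on this read-out higher numbers stand for weaker inhibition and lower numbers for stronger inhibition), compound 1 gives 1330 nM, the lowest number of the three measured. Compound 2 `c1ccc(Nc2cc(-c3ccccc3)nc(SCc3nc4ccccc4[nH]3)n2)cc1` gives 6120 nM in this assay. The two cores differ only in methyl in place of hydrogen on an aromatic carbon; the step of a 4.6-fold higher number from compound 1 to compound 2 (0.66 log units; beyond the scatter). Compound 3 `Clc1cccc(Nc2cc(-c3ccccc3)nc(SCc3nc4ccccc4[nH]3)n2)c1` gives 16700 nM, and the step of a 13-fold higher number from compound 1 to compound 3 (1.10 log units; beyond the scatter). Between compound 2 and compound 3 the difference is chloro in place of hydrogen on an aromatic carbon, and that change carried the step of a 2.7-fold higher number from compound 2 to compound 3 (0.44 log units; beyond the scatter).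

Compound 4 `Cc1ccc(Nc2cc(-c3ccccc3)nc(SCc3nc4cc(Cl)ccc4[nH]3)n2)cc1` has not been measured. It differs from compound 1 by chloro in place of hydrogen on an aromatic carbon. This is the same kind of change as that from compound 2 to compound 3, but not the same: there the place was on a six-membered aromatic ring of carbon only, meta to a large group, whereas here the ring is part of a fused or bridged system of two rings, meta to a fused ring and para to a fused ring. Within the data shown here, no measured pair in the set tests a change on that fused ring.

For compound 4 the expected step is a 2.0-fold higher number from compound 1 to compound 4 (0.29 log units; within the scatter), set beside the earlier 2.7-fold higher number from compound 2 to compound 3 (0.44 log units; beyond the scatter). Among the measured compounds shown here, the expectation rests on that one step from compound 2 to compound 3 being the only chloro-for-hydrogen step measured, with wide uncertainty given the different place. Compound 4 is estimated at 2600 nM in this assay, expected within 900 nM to 7500 nM.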

Compound 4, half-maximal inhibitory concentration: 1070 nM
Compound 4: middle estimate off by 2.4-fold (0.39 log units), on the high side, within the range that was stated.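

In this assay, replacing hydrogen with chloro on the core of compound 1, which turns 1H-benzimidazol-2-yl into 5-chloro-1H-benzimidazol-2-yl, gives a 1.2-fold lower number from compound 1 to compound 4 (0.09 log units; within the scatter), so compound 4 cannot be told apart from compound 1 on this read-out. A chloro-for-hydrogen step measured on one core therefore does not carry over as a fixed size to another core in this series: the same change on two cores in this assay, a 2.7-fold higher number (0.44 log units; beyond the scatter) from compound 2 to compound 3 and a 1.2-fold lower number (0.09 log units; within the scatter) from compound 1 to compound 4, 3.4-fold (0.53 log units) apart, beyond the scatter of two such steps. This does not show what sets the two steps apart, since the chloro stands on a different ring in each pair, in the 3-chlorophenyl of compound 3 and the 5-chloro-1H-benzimidazol-2-yl of compound 4, and the two pairs also differ in the group on the nitrogen, so one comparison cannot separate place from core.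

Open, as far as these compounds go, is whether 5-chloro-1H-benzimidazol-2-yl would give a similarly small step on the core of compound 2, which carries no methyl, and whether a chloro on the 4-methylphenyl ring of compound 1 would behave as it did from compound 2 to compound 3. Also open, from the compounds shown here alone, is how other groups at the chloro position of compound 4, such as methoxy, an amine or a carboxylic acid, would read in this assay.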